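Working notes: from compound 2 to compound 4

The source may report more compounds than this note shows. Statements on the series, on what has been measured and on what is new or still open speak of the compounds shown alone.

Compound 2 `O=C1O[C@H]([C@@H](O)Cn2cc(CCO)nn2)C(OCc2ccccc2)=C1OCc1ccccc1` in a functional assay on SW-620 cells (Homo sapiens) for antiproliferative activity, read by MTT assay, with a stated time of 72 h (on this read-out higher numbers stand for weaker inhibition and lower numbers for stronger inhibition), gives > 100000 nM, which is a limit of the assay and not a number. Compound 1 `COc1ccc(-c2cn(C[C@H](O)[C@H]3OC(=O)C(OCc4ccccc4)=C3OCc3ccccc3)nn2)cc1` gives 58200 nM and compound 3 `O=C1O[C@H]([C@@H](O)Cn2cc(-c3cc(C(F)(F)F)cc(C(F)(F)F)c3)nn2)C(OCc2ccccc2)=C1OCc1ccccc1` gives 49200 nM in this assay. Among the compounds with values here, the only measured step that bears on the series is an at least 1.7-fold higher number from compound 1 to compound 2 (0.23 log units; that floor lies within the scatter), and its floor rests on (the limit of > 100000 nM in this assay, at which 1 of the 3 values shown sits). Compound 4 `CCCCc1cn(C[C@H](O)[C@H]2OC(=O)C(OCc3ccccc3)=C2OCc2ccccc2)nn1` differs from compound 2 by ethyl in place of hydroxy on a saturated chain carbon, two bonds along the chain from an aromatic carbon. Leaving the hydroxy group behind runs in the reverse sense of that step, so a modest lowering of the number is expected, an at least 1.5-fold lower number from compound 2 to compound 4 (0.18 log units; that floor lies within the scatter). Compound 2 itself is known only as a limit, which makes the expectation loose. Compound 4 is therefore estimated at 65000 nM, in the range 25000 nM to 150000 nM.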

Compound 4, half-maximal inhibitory concentration: 47500 nM
Compound 4: middle estimate off by 1.4-fold (0.14 log units), on the high side, and the stated range covers the measured number.
By their numbers in this assay, from the lowest: compounds 4, 3 and 1 (each within the scatter of the next). At a limit, above all of these: compound 2.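

In this assay, within the data shown here, ethyl in place of hydroxy on the saturated chain carbon gives an at least 2.1-fold lower number from compound 2 to compound 4 (0.32 log units; beyond the scatter), the first step to clear the scatter. Compound 2 is a limit and not a number, so that step is only a floor: the limit of > 100000 nM in this assay, at which 1 of the 4 values shown sits. Butyl and 4-methoxyphenyl on the aromatic carbon are not told apart, with a 1.2-fold lower number from compound 1 to compound 4 (0.09 log units; within the scatter).

The compounds shown leave open whether a longer alkyl chain, or an amine or carboxylic acid at the chain end, moves the number. Going by these compounds, the true size of the step from compound 2 also stays open.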